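A few compounds are considered here, and "the series" means these few. Any claim that something is new, unique, unknown or untested is made for them only; others in the source may bear on it.

In a functional assay on HT-29 cells (Homo sapiens) for antiproliferative activity, read by sulforhodamine B assay, with a stated time of 48 h (on this read-out higher numbers stand for weaker inhibition and lower numbers for stronger inhibition), compound 1 (`CN1CCN(c2ccc(S(=O)(=O)Oc3cccc(Br)c3)cc2)C1=O`) gives 1300 nM while compound 2 (`CCCCN1CCN(c2ccc(S(=O)(=O)Oc3cccc(OC)c3)cc2)C1=O`) gives 13000 nM and compound 3 (`CCCCN1CCN(c2ccc(S(=O)(=O)Oc3cccc(Br)c3)cc2)C1=O`) gives 16000 nM on the same read-out. Compound 3 and compound 2 lie within the scatter of each other, and both numbers are well above that of compound 1. Compound 4 (`CCCCN1CCN(c2ccc(S(=O)(=O)Oc3cc(F)cc(F)c3)cc2)C1=O`) keeps the butyl chain of compound 3 but carries 3,5-difluorophenyl in place of 3-bromophenyl on an oxygen. For the measured compounds named here, the one measured change on this group is a 1.2-fold higher number from compound 2 to compound 3 (0.09 log units; within the scatter) for bromo in place of methoxy, and it stays within the scatter. The large step, a 12-fold higher number from compound 1 to compound 3 (1.09 log units; beyond the scatter) for propyl in place of hydrogen, concerns the chain, which does not change here. This single small step is thin evidence for a new group, so no step beyond the scatter is expected in this assay at this stage. The estimated step is a 1.3-fold lower number from compound 3 to compound 4 (0.12 log units; within the scatter) and so stays within the scatter. For compound 4 the estimated value is 12000 nM with an expected range from 4000 nM to 30000 nM in this test.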

Compound 4, half-maximal inhibitory concentration: > 100000 nM
Compound 4 was reported as a limit; the forecaster's own chance of this, stated with the estimate: 10%; at least 8.3-fold (0.92 log units) between middle value and limit.
By their numbers in this assay, from the lowest: compound 1; then compounds 2 and 3 (each within the scatter of the next). At a limit, above all of these: compound 4.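

In this assay compound 4 is reported only as a limit, not as a number: the limit of > 100000 nM in this assay, at which 1 of the 4 values shown sits. The group on the oxygen bound to the sulfonyl sulfur does affect the read-out: 3,5-difluorophenyl in place of 3-bromophenyl gives an at least 6.2-fold higher number from compound 3 to compound 4 (0.79 log units; beyond the scatter), and 3,5-difluorophenyl in place of 3-methoxyphenyl gives an at least 7.6-fold higher number from compound 2 to compound 4 (0.88 log units; beyond the scatter). For the compounds shown here, the only earlier change at this place, bromo in place of methoxy, gave a 1.2-fold higher number from compound 2 to compound 3 (0.09 log units; within the scatter), so that step alone understated how much this position can matter when the butyl chain is kept.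

The compounds shown leave open whether this shift comes from carrying two fluoro groups or from replacing the single bromo or methoxy group, a question a 3-fluorophenyl group could help to settle. As far as these compounds go, whether 3,5-difluorophenyl acts the same way with the shorter chain of compound 1 also stays open.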